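From morpholin-4-yl to 4-hydroxypiperidin-1-yl on compound 3

The source may hold more compounds than are shown below. What is called first, only, known or untested is meant among the compounds shown, and "the series" means these compounds.

Of the compounds shown here, three that share one core have been measured in a functional assay on PC-3 cells (Homo sapiens) for inhibition, read by sulforhodamine B assay, with a stated time of 72 h; a lower number here means a stronger inhibitor of growth, a higher number a weaker inhibitor of growth. Compound 1 `COc1ncc(-c2ccc3nccc(/C(C)=C/C(=O)N4CCN(C)CC4)c3c2)cc1NS(=O)(=O)c1ccc(F)cc1F` gives 360 nM, compound 2 `COc1ncc(-c2ccc3nccc(/C=C/C(=O)N4CCN(C)CC4)c3c2)cc1NS(=O)(=O)c1ccc(F)cc1F` gives 450 nM, and compound 3 `COc1ncc(-c2ccc3nccc(/C(C)=C/C(=O)N4CCOCC4)c3c2)cc1NS(=O)(=O)c1ccc(F)cc1F` gives 1670 nM. Compound 3 has the highest number of the three, which makes it the weakest inhibitor of growth in this small set.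

Compound 4 `COc1ncc(-c2ccc3nccc(/C(C)=C/C(=O)N4CCC(O)CC4)c3c2)cc1NS(=O)(=O)c1ccc(F)cc1F` differs from compound 3 in one place, where 4-hydroxypiperidin-1-yl stands in place of morpholin-4-yl on a carbonyl carbon: 4-hydroxypiperidin-1-yl in place of morpholin-4-yl on a carbonyl carbon.

The closest evidence is a change at the same carbonyl carbon, where morpholin-4-yl replaces 4-methylpiperazin-1-yl, giving a 4.6-fold higher number from compound 1 to compound 3 (0.67 log units; beyond the scatter). The step of a 3.7-fold higher number from compound 2 to compound 3 (0.57 log units; beyond the scatter) is of similar size, but it also involves the methyl group on the ethenyl chain. Removing that methyl group alone gives a 1.3-fold higher number from compound 1 to compound 2 (0.10 log units; within the scatter), which is within the scatter. Within the data shown here, changing the ring on the carbonyl has therefore produced modest steps so far. Among the measured compounds shown here, no measured compound carries 4-hydroxypiperidin-1-yl, so the data give no direction for this swap, and no shift beyond the scatter is expected in this assay.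

The expected step is a 1.4-fold lower number from compound 3 to compound 4 (0.14 log units; within the scatter). For compound 4 the estimated value is 1200 nM, with an expected range of 450 nM to 3000 nM.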

Compound 4, concentration for 50% growth inhibition: 1080 nM
Beside the measured number, compound 4's estimate is 1.1-fold (0.05 log units) above it; measured number inside the range.
By their numbers in this assay, from the lowest: compounds 1 and 2 (each within the scatter of the next); then compounds 4 and 3 (each within the scatter of the next).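

In this assay, 4-hydroxypiperidin-1-yl in place of morpholin-4-yl on the carbonyl carbon gives a 1.5-fold lower number from compound 3 to compound 4 (0.19 log units; within the scatter), so these two rings cannot be told apart at this position. Both rings stand apart from 4-methylpiperazin-1-yl: that ring's replacement by 4-hydroxypiperidin-1-yl gives a 3.0-fold higher number from compound 1 to compound 4 (0.48 log units; beyond the scatter), and the comparison with the chain lacking the methyl group gives a 2.4-fold higher number from compound 2 to compound 4 (0.38 log units; beyond the scatter), although that step changes the ring and the chain methyl together. Among these four compounds, the two carrying 4-methylpiperazin-1-yl therefore have the lower numbers, and none goes against this, but no available measurement explains the difference.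

What remains open is which part of 4-methylpiperazin-1-yl matters, since the compounds shown do not separate its ring nitrogen from the methyl group on it. A plain piperazin-1-yl ring, 4-aminopiperidin-1-yl or an open-chain amine such as dimethylamino at the same carbonyl carbon would help to separate them, and 4-hydroxypiperidin-1-yl on the chain lacking the methyl group would show whether that methyl group still makes little difference with this ring.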